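Sulfonyl aryl swap on the shared core: compound 4

The source may hold more compounds than are shown below. What is called first, only, known or untested is meant among the compounds shown, and "the series" means these compounds.

Compound 2 `COc1ccc(-c2c(S(=O)(=O)c3ccc(F)c(F)c3)cnc3cc(F)ccc23)cc1` is the anchor of this note. Among the measured compounds shown here, in an ADME assay on microsomes from liver (Homo sapiens) for metabolic stability, tested at 2.5 uM (on this read-out higher numbers stand for fast clearance and lower numbers for slow clearance), compound 2 gives 1.1 mL/min, the second highest of the three numbers measured so far. Compound 1 `Cc1ccc(S(=O)(=O)c2cnc3c(F)cccc3c2-c2cccc(F)c2)cc1F` gives 3.92 mL/min in this assay, the highest of the set. For the measured compounds named here, compound 3 `O=S(=O)(c1ccc(F)c(F)c1)c1cnc2cc(F)ccc2c1-c1ccc(Cl)cc1` gives 0.01 mL/min, the lowest, and the only one-place step measured, a 110-fold lower number from compound 2 to compound 3 (2.04 log units; beyond the scatter), is that drop, brought about by chloro in place of methoxy on an aromatic carbon.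

Compound 4 `COc1ccc(-c2c(S(=O)(=O)c3cc(F)cc(F)c3)cnc3cc(F)ccc23)cc1` keeps the methoxy of compound 2 and changes only the aryl on the sulfonyl sulfur: 3,5-difluorophenyl in place of 3,4-difluorophenyl on a sulfonyl sulfur. Going by the values given here, no measured pair reports a change of the group on the sulfonyl sulfur; the one measured step concerns a different ring, so it does not bear on this swap and offers no direction for it. With nothing to anchor a direction, the expected step of no change at the digits printed from compound 2 to compound 4 (within the scatter) is none beyond the scatter. Among the compounds with values here, compound 4 is therefore estimated at 1.1 mL/min in this assay, with a range from 0.35 mL/min to 3.5 mL/min; the range is set wide, as no measured step touches this change.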

Compound 4, intrinsic clearance in a liver preparation (reported as CLH), per the amount of preparation that the assay uses: 1.51 mL/min
The estimate for compound 4 lay 1.4-fold (0.14 log units) below the measured number, and the stated range covers the measured number.
By their numbers in this assay, from the lowest: compound 3; then compounds 2 and 4 (each within the scatter of the next); then compound 1.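

Among the compounds shown here, this is the first measured change to the group on the sulfonyl sulfur. In this assay, 3,5-difluorophenyl in place of 3,4-difluorophenyl gives a 1.4-fold higher number from compound 2 to compound 4 (0.14 log units; within the scatter), so this rearrangement of the same atoms on the aryl group leaves the clearance read-out of the methoxy compounds within the usual scatter. Set against a 110-fold lower number from compound 2 to compound 3 (2.04 log units; beyond the scatter), the one step so far that lies beyond the scatter and arises on a different ring, the two difluorophenyl arrangements on the sulfonyl sulfur cannot be told apart here, although this rests on a single pair and no measurement at hand explains either step.

Still open, on these data alone, is whether 3,5-difluorophenyl gives a similar result when chloro stands in place of methoxy, as in compound 3, whose clearance number lies far below those of the methoxy pair. The compounds shown also leave open how the read-out responds to a more different group on the sulfonyl sulfur, such as a phenyl ring bearing an amine or a carboxylic acid, since both aryl groups compared here carry only fluorine.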